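Swapping a Ring for a Chain on a Shared Core

A few compounds are considered here, and "the series" means these few. Any claim that something is new, unique, unknown or untested is made for them only; others in the source may bear on it.

Compound 1 `CSc1nc(CCO)cc(N2CCCC2)n1` carries a pyrrolidin-1-yl group on its shared core. In an ADME assay on Vero cells (Chlorocebus sabaeus) for cytotoxicity, with a stated time of 48 h (a higher number here means that more compound is tolerated, a lower number that less compound is tolerated), compound 1 gives 523000 nM, the highest of the three numbers recorded so far. Compound 3 `C=CCNc1nc(SC)nc(CCO)c1Br` gives 411000 nM, which lies within the usual scatter of that figure. Compound 2 `C=CCN(CC=C)c1cc(CCO)nc(SC)n1` gives 249000 nM, a gap beyond the scatter. Compound 4 `C#CCNc1cc(CCO)nc(SC)n1` has not yet been tested; it differs from compound 1 by propargylamino in place of pyrrolidin-1-yl on an aromatic carbon. For the measured compounds named here, no measured pair in this set isolates that change, so the expectation rests only on the spread seen among the three. Compound 4 is expected to give 400000 nM, with a range from 200000 nM to 800000 nM. That estimate implies a 1.3-fold lower number from compound 1 to compound 4 (0.12 log units; within the scatter), expected to be a small downward move within the scatter.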

Compound 4, half-maximal cytotoxic concentration: 1120000 nM
Compound 4: middle estimate off by 2.8-fold (0.45 log units), on the low side; measured number above the stated range.
By their numbers in this assay, from the lowest: compounds 2, 3 and 1 (each within the scatter of the next, the first and the last beyond it); then compound 4.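

On this aromatic carbon, propargylamino in place of pyrrolidin-1-yl gives a 2.1-fold higher number from compound 1 to compound 4 (0.33 log units; beyond the scatter) in this assay, the first sign that this single position can shift how much compound is tolerated. The change removes a ring, adds a triple bond and adds a hydrogen-bond donor, and one step cannot separate these three. No measurement here accounts for the rise. Still open, from the compounds shown here alone, is whether a propylamino group, which has no triple bond, or a morpholin-4-yl ring in the same place would track compound 4 or compound 1.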